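The compounds below may be only part of what the source reports. "The series", "measured", "known", "first", "only" and "open" are said of these compounds alone.

In an ADME assay on Vero cells (Chlorocebus sabaeus) for cytotoxicity, read by MTT assay, with a stated time of 72 h (on this read-out lower numbers stand for higher toxicity in this test and higher numbers for lower toxicity in this test), compound 1 `C/C(=N/NC(=S)N(Cc1ccccc1)Cc1ccccc1)c1ccccc1` gives 167000 nM. Compound 2 `S=C(N/N=C\c1ccc(Cl)cc1)N(Cc1ccccc1)Cc1ccccc1`, the starting point of this step, gives 159000 nM in this assay. Of the two numbers shown, compound 2 sits at the lower end, yet the gap to compound 1 lies within the usual scatter, so the two cannot be told apart. Compound 3 `C=CCN(CC=C)C(=S)N/N=C\c1ccccc1C` yields in this assay only a limit of the assay, > 228000 nM, and no number. For the measured compounds named here, the single step between measured compounds that differ in one place is a 1.1-fold lower number from compound 1 to compound 2 (0.02 log units; within the scatter), a swap on an amide-type nitrogen that left the read-out where it was.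

Compound 4 `O=[N+]([O-])c1ccc(/C=N\NC(=S)N(Cc2ccccc2)Cc2ccccc2)o1` is still to be measured. It differs from compound 2 by 5-nitrofuran-2-yl in place of 4-chlorophenyl on a carbon with a double bond to nitrogen. Going by the values given here, no measured step touches this position, since the one step known sits on an amide-type nitrogen, and the evidence the limit of > 228000 nM in this assay, at which 1 of the 3 values shown sits, speaks only of a limit. With nothing pointing in either direction, compound 4 is expected to stay near compound 2, an estimated step of a 1.3-fold lower number from compound 2 to compound 4 (0.12 log units; within the scatter), though with wide uncertainty. For compound 4 the estimate in this assay is 120000 nM, with a range from 35000 nM to 250000 nM.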

Compound 4, half-maximal cytotoxic concentration: 158000 nM
Beside the measured number, compound 4's estimate is 1.3-fold (0.12 log units) below it, within the range that was stated.
By their numbers in this assay, from the lowest: compounds 4, 2 and 1 (each within the scatter of the next). At a limit, above all of these: compound 3.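

At the carbon with a double bond to nitrogen, 5-nitrofuran-2-yl is a very different group from 4-chlorophenyl: a six-membered aromatic ring of carbon only gives way to a five-membered aromatic ring with a hetero atom, and hydrogen-bond acceptors enter where the old group had none. Even so, this assay shows a 1.0-fold lower number from compound 2 to compound 4 (0.00 log units; within the scatter), which gives this position its first measured step and shows that this large change in structure leaves the read-out unchanged within the scatter, just as the earlier swap on the amide-type nitrogen did. Nothing measured in this set explains why the number holds steady across this change.

The compounds shown leave open whether this flat result extends to quite different groups on the same carbon, such as a carboxylic acid, an amine or a longer chain in place of the aromatic ring. They also leave open whether 5-nitrofuran-2-yl would behave the same way on a compound that carries something other than the two benzyl groups on the amide-type nitrogen.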